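Replacing a cyclohexyl ether with a chlorinated aryl ether

The source may report more compounds than this note shows. Statements on the series, on what has been measured and on what is new or still open speak of the compounds shown alone.

Compound 1 `Cc1cn(C2CCN(Cc3cccc(OC4CCCCC4)c3)CC2)c(=O)[nH]c1=O` is the only one of the three measured compounds to give a number in an ADME assay on MRC5 cells (Homo sapiens) for cytotoxicity, read by fluorescence and resazurin assay, with a stated time of 3 days; a lower number here means a stronger inhibitor, a higher number a weaker inhibitor: compound 1 gives 23600 nM. Compound 2 `Cc1cn(C2CCN(Cc3cncc(Oc4ccccc4)c3)CC2)c(=O)[nH]c1=O` reaches only a limit of the assay; in this assay compound 2 gives > 64000 nM. Compound 3 `Cc1cn(C2CCN(Cc3cncc(Oc4cccc(Cl)c4)c3)CC2)c(=O)[nH]c1=O` likewise stops at a limit, giving > 64000 nM in this assay. The step that the two limits leave unreadable from compound 2 to compound 3 cannot be read, as both ends sit at the limit of > 64000 nM in this assay, at which 2 of the 3 values shown sit. Compound 4 `Cc1cn(C2CCN(Cc3cccc(Oc4ccc(Cl)c(C(F)(F)F)c4)c3)CC2)c(=O)[nH]c1=O` differs from compound 1 in one place: 4-chloro-3-(trifluoromethyl)phenyl in place of cyclohexyl on an oxygen on an aromatic ring. Among the compounds with values here, no measured step covers this exchange, so the expectation is for no step beyond the scatter, with a fair chance that compound 4 also reaches only the limit. Compound 4 is therefore estimated at 30000 nM, within 10000 nM to 80000 nM, a step of a 1.3-fold higher number from compound 1 to compound 4 (0.10 log units; within the scatter) expected to stay small.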

Compound 4, half-maximal inhibitory concentration: 5280 nM
The estimate for compound 4 lay 5.7-fold (0.75 log units) above the measured number, and the stated range ends above it.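

The exchange on the oxygen brings a 4.5-fold lower number from compound 1 to compound 4 (0.65 log units; beyond the scatter) in this assay and so shows that this place can move the number beyond the scatter, which no earlier readable step had shown. For this one pair, 4-chloro-3-(trifluoromethyl)phenyl goes with a stronger effect on the cells than cyclohexyl. No measurement shown accounts for this step.

Still open, as far as these compounds go, is whether the ring itself or its chloro and trifluoromethyl groups carry the step, which plain phenyl on the core of compound 1 could separate. From the compounds shown here alone, how an amine or a carboxylic acid at this place would read also remains open.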